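The source may hold more compounds than are shown below. What is called first, only, known or untested is meant among the compounds shown, and "the series" means these compounds.

Series notes. Compound 1 `Cc1nc2c([nH]1)C(=O)/C(=N/c1ccc(F)cc1)C(Cl)=C2O` and compound 2 `Cc1nc2c([nH]1)C(=O)/C(=N/c1ccc(C(F)(F)F)cc1)C(Cl)=C2O` share one core and differ only in the group on the six-membered aromatic ring of carbon only. In a functional assay on NIH3T3 cells (Mus musculus) for antiproliferative activity (a higher number here means a weaker inhibitor, a lower number a stronger inhibitor), compound 1 gives 1200 nM and compound 2 gives 1100 nM. The single step measured so far, a 1.1-fold lower number from compound 1 to compound 2 (0.04 log units; within the scatter), moves the number by less than the scatter, so on the two numbers shown compound 2 stands level with compound 1; the gap between them carries no information about direction.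

Compound 3 `Cc1nc2c([nH]1)C(=O)/C(=N/c1ccc(I)cc1)C(Cl)=C2O` is the next member. Its change from compound 2 is iodo in place of trifluoromethyl on an aromatic carbon. Within the data shown here, the only measured step that bears on this position is a 1.1-fold lower number from compound 1 to compound 2 (0.04 log units; within the scatter), which also exchanged one group for another at the same aromatic carbon and left the read-out where it was. Nothing measured points to a large move at this place in either direction, so the expected step for compound 3 is a 1.2-fold lower number from compound 2 to compound 3 (0.06 log units; within the scatter), a shift within the scatter. Compound 3 is estimated at 950 nM in this assay, with a range of 350 nM to 2600 nM.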

Compound 3, half-maximal inhibitory concentration: 600 nM
Beside the measured number, compound 3's estimate is 1.6-fold (0.20 log units) above it; the range from low to high includes it.
By their numbers in this assay, from the lowest: compounds 3, 2 and 1 (each within the scatter of the next).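

In this assay, iodo at this aromatic carbon gives a 1.8-fold lower number from compound 2 to compound 3 (0.26 log units; within the scatter) and a 2.0-fold lower number from compound 1 to compound 3 (0.30 log units; within the scatter), and since both steps lie within the scatter, the three compounds stand level on these numbers. Among these compounds, compound 3 adds a third group to the comparison at this place: one iodine atom replaces the four heavy atoms of trifluoromethyl, and the read-out still shows no step beyond the scatter, so fluoro, trifluoromethyl and iodo cannot be separated here, even though the step between fluoro and iodo is the largest measured so far. No independent measurement is available to account for the size of either step.

Iodo and trifluoromethyl both have no hydrogen-bond donors or acceptors, no ring and no net charge, so it remains open whether an amine or a carboxylic acid at this aromatic carbon would move the number beyond the scatter. Among the compounds shown here, also open is whether a change elsewhere on the shared core would produce a step beyond the scatter, as every measured step so far lies at this one position.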